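A few compounds are considered here, and "the series" means these few. Any claim that something is new, unique, unknown or untested is made for them only; others in the source may bear on it.

Measured compounds in this study:

compound 1, `CC[C@@H]1C(=O)N(C)c2cnc(Nc3ccc(S(=O)(=O)NCCO)cc3)nc2N1C1CCCC1` — 546 nM
compound 2, `CC[C@@H]1C(=O)N(C)c2cnc(-n3ccc4cc(C(=O)NC(C)C)ccc43)nc2N1C1CCCC1` — 786 nM
compound 3, `CCC1C(=O)N(C)c2cnc(Nc3ccc(S(N)(=O)=O)cc3)nc2N1c1ccn(C)n1` — "not active" (no number reported)

All three were tested in a functional assay on K562 cells (Homo sapiens) for antiproliferative activity, read by CCK-8 assay, with a stated time of 72 h; a higher number here means a weaker inhibitor of growth, a lower number a stronger inhibitor of growth. Compound 1 gives 546 nM and compound 2 gives 786 nM. These two numbers lie within the usual scatter of each other, so neither compound can be called the stronger or weaker one. Compound 3 gave no number at all and was simply reported as not active. No pair among these three compounds differs in only one place, so there is no single measured step to learn from.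

Compound 4, `CCCNC(=O)c1ccc2c(ccn2-c2ncc3c(n2)N(C2CCCC2)[C@H](CC)C(=O)N3C)c1`, has not yet been measured. It differs from compound 2 in one way: propyl in place of isopropyl on an amide-type nitrogen. The two compounds have the same atoms joined differently, and the counted features of the group stay the same. Among the measured compounds shown here, nothing among the measured compounds shows what such a change does in this assay, so the expectation rests on the smallness of the change alone. The expected step is a 1.0-fold higher number from compound 2 to compound 4 (0.01 log units; within the scatter), which is no more than the scatter in either direction. Compound 4 is therefore expected to give about 800 nM, most likely between 350 nM and 1800 nM in this assay.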

Compound 4, concentration for 50% growth inhibition: 395 nM
For compound 4 the middle estimate is 2.0-fold (0.31 log units) above the measured one; the measured number falls inside the stated range.
By their numbers in this assay, from the lowest: compounds 4, 1 and 2 (each within the scatter of the next).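

Putting propyl in place of isopropyl on the amide-type nitrogen gives a 2.0-fold lower number from compound 2 to compound 4 (0.30 log units; within the scatter) in this assay. Among the compounds shown here, this is the first pair in the set that differs in only one place, and it shows that rejoining these same three carbon atoms, with the counted features of the group unchanged, does not move the number beyond the scatter, so compound 2 and compound 4 cannot be told apart as growth inhibitors here. Nothing measured alongside these numbers bears on this result, so it stands as a plain observation without an explanation.

Only these two chains are shown on this nitrogen, so the compounds leave open how a longer chain such as butyl, a ring such as cyclopropyl, or a chain ending in an amine would read in this assay. On these data alone, it is also open whether the propylcarbamoyl group is needed at all, a question that a compound carrying a carboxylic acid in its place could begin to answer.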